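The source may report more compounds than this note shows. Statements on the series, on what has been measured and on what is new or still open speak of the compounds shown alone.

Within the data shown here, compound 2 `Cc1c(F)c(Oc2cccc(N)c2)nc(Oc2cccc(C(=N)N)c2)c1F` is one of two compounds measured in an assay on isolated protein for inhibition of serine protease 1 (Bos taurus); on this read-out higher numbers stand for weaker inhibition and lower numbers for stronger inhibition. In this assay compound 2 gives > 5000 nM, which is a limit of the assay and not a number. Its partner, compound 1 `Cc1c(F)c(Oc2cccc(C(=N)N)c2)nc(Oc2cccc([N+](=O)[O-])c2)c1F`, differs from compound 2 only in carrying a nitro group where compound 2 carries an amino group. In this assay compound 1 gives > 5000 nM, again a limit of the assay. The step that the two limits leave unreadable from compound 1 to compound 2 therefore cannot be read, because of the limit of > 5000 nM in this assay, at which 2 of the 2 values shown sit. Compound 3 `Cc1c(F)c(Oc2cccc(C(=N)N)c2)nc(Oc2cccc(C(=O)O)c2)c1F` has not been measured; it differs from compound 2 by carboxy in place of amino on an aromatic carbon. Among the measured compounds shown here, no measured step gives a direction for this change, so the expected step that the limit leaves unreadable from compound 2 to compound 3 is set at no clear movement and carries wide uncertainty. On this basis compound 3 is expected to give about 8000 nM in this assay, within 1500 nM to 40000 nM, most likely as another limit.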

Compound 3, inhibition constant: > 5000 nM
Compound 3 ended at the assay's limit; the forecaster's own chance of this, stated with the estimate: 75%; the middle value does not contradict the limit.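

Among these compounds, no step between compound 1, compound 2 and compound 3 can be read in this assay, because all three stop at the same limit: the limit of > 5000 nM in this assay, at which 3 of the 3 values shown sit. The compounds shown leave open how strongly each one inhibits the protease, and whether nitro, amino and carboxy differ at all in their effect on inhibition.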